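A few compounds are considered here, and "the series" means these few. Any claim that something is new, unique, unknown or untested is made for them only; others in the source may bear on it.

In a toxicity assay on NIH3T3 cells (Mus musculus) for cytotoxicity, read by resazurin assay (on this read-out higher numbers stand for an effect only at larger amounts of compound and lower numbers for an effect already at smaller amounts), compound 1 `CC(=O)c1ccc(NCc2cncn2Cc2ccc(-c3ccccc3)cc2)cc1-c1ccccc1` gives > 10000 nM, which is a limit of the assay and not a number. Compound 2 `COc1ccc(NCc2cncn2Cc2ccc(-c3ccccc3)cc2N)cc1-c1ccccc1` gives > 1000 nM, likewise a limit. Compound 3 `COC(=O)c1ccc(NCc2cncn2Cc2ccccc2)cc1-c1ccccc1` gives > 1000 nM, also a limit. Compound 1 therefore stands without an exact value, as do the other two. Compound 4 `O=C(c1ccc(NCc2cncn2Cc2ccc(-c3ccccc3)cc2)cc1-c1ccccc1)N1CCCCC1` has piperidin-1-yl in place of methyl on a carbonyl carbon, changing acetyl to (piperidin-1-yl)carbonyl (piperidin-1-yl in place of methyl on a carbonyl carbon). Within the data shown here, no measured pair shows this change, so no step beyond the scatter is expected in this assay, in either direction. This expectation rests on compound 1, whose limit is > 10000 nM. The expected a number no higher from compound 1 to compound 4 (the limit leaves the size open) is correspondingly small. Compound 4 is estimated at 10000 nM, with an expected range from 3000 nM to 30000 nM.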

Compound 4, half-maximal effective concentration: > 1000 nM
Compound 4: no number, only a limit; the forecaster's own chance of this, stated with the estimate: 75%; the middle value lies beyond the limit too.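

Among these compounds, compound 1 and compound 4 both carry only limits and no numbers, and no step between them can be read in this assay. The compounds shown leave open at what amount any of them would show an effect.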